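Amide-linked aryl series: varying the para substituent

The source may report more compounds than this note shows. Statements on the series, on what has been measured and on what is new or still open speak of the compounds shown alone.

Measured so far in a functional assay on CLL cells (Homo sapiens) for cytotoxicity, read by MTT assay, with a stated time of 48 h; a higher number here means that more compound is needed for the effect, a lower number that less compound is needed:
compound 1, `C=C(CC)C(=O)c1ccc(OCC(=O)Nc2ccc(C(N)=O)cc2)c(Cl)c1Cl` — 3700 nM
compound 2, `C=C(CC)C(=O)c1ccc(OCC(=O)Nc2ccc(C(=O)OC)cc2)c(Cl)c1Cl` — 4100 nM
compound 3, `C=C(CC)C(=O)c1ccc(OCC(=O)Nc2ccc(O)cc2)c(Cl)c1Cl` — 6400 nM

All three compounds share the same core and differ only in the group on the aromatic carbon of the terminal ring. The three numbers lie close together: the step from compound 1 to compound 2 is a 1.1-fold higher number from compound 1 to compound 2 (0.04 log units; within the scatter), from compound 1 to compound 3 it is a 1.7-fold higher number from compound 1 to compound 3 (0.24 log units; within the scatter), and from compound 2 to compound 3 it is a 1.6-fold higher number from compound 2 to compound 3 (0.19 log units; within the scatter). For the measured compounds named here, compound 3 therefore carries the highest of the three numbers, but no step separates it from compound 1 or compound 2 beyond the scatter, so no order among them can be read.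

Compound 4, `C=C(CC)C(=O)c1ccc(OCC(=O)Nc2ccc(/C=C/C(=O)OCC)cc2)c(Cl)c1Cl`, is not yet measured. Against compound 3 the change is 2-(ethoxycarbonyl)ethenyl in place of hydroxy on an aromatic carbon. Going by the values given here, the steps that bear on it are those that exchanged the group at this same aromatic carbon: from compound 1 to compound 3 and from compound 2 to compound 3, both within the scatter, as is the exchange between compound 1 and compound 2. Three different groups at this position left this assay essentially unchanged, so for compound 4 a step of about a 1.4-fold lower number from compound 3 to compound 4 (0.15 log units; within the scatter) is expected, that is, none beyond the scatter. The estimated value for compound 4 in this assay is 4500 nM, within 2000 nM to 11000 nM.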

Compound 4, half-maximal effective concentration: 1700 nM
Estimate against measurement, compound 4: 2.6-fold (0.42 log units) above, and the stated range ends above it.
By their numbers in this assay, from the lowest: compound 4; then compounds 1, 2 and 3 (each within the scatter of the next).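

In this assay this aromatic carbon proves less indifferent to exchange than the hydroxy, carbamoyl and methoxycarbonyl compounds suggested: 2-(ethoxycarbonyl)ethenyl gives a 3.8-fold lower number from compound 3 to compound 4 (0.58 log units; beyond the scatter) and a 2.4-fold lower number from compound 2 to compound 4 (0.38 log units; beyond the scatter) and a 2.2-fold lower number from compound 1 to compound 4 (0.34 log units; beyond the scatter) as its three steps. For the compounds shown here, compound 4 is thus the only one of the four compounds separated from all the others, so a change at this carbon can move the number, though each step remains modest. No accompanying measurement accounts for these steps.

The compounds shown leave open whether the step belongs to the ethenyl unit, to the ester or to the two together, a question that a saturated ethyl chain carrying the same ester, or a carboxylic acid or primary amide in place of the ethyl ester, would address. Also open, as far as these compounds go, is whether a longer chain or a bulkier ester, such as a tert-butyl ester, would lower the number further or return it to the range of compounds 1, 2 and 3.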